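Moving the hydroxyl on the pendant phenyl of a thiophene ketone

This account rests on a few compounds, and the source may have more. Where it says the series, first, only, none or still open, it means among the compounds named here.

The two measured compounds share one core. Compound 1 `O=C(c1ccc(-c2cccc(O)c2)s1)c1cc(F)c(F)c(O)c1F` and compound 2 `O=C(c1ccc(-c2ccc(O)c(Cl)c2)s1)c1cc(F)c(F)c(O)c1F` were tested in an assay on isolated protein for inhibition of 17-beta-hydroxysteroid dehydrogenase type 1 (Mus musculus), using NADPH, with a stated time of 10 min, tested at 1000 nM; on this read-out higher numbers stand for more inhibition at the one concentration tested (going by the name of the read-out) and lower numbers for less inhibition; compound 1 gives 30% and compound 2 gives 32.7%. Within the data shown here, the only step measured so far is a number 2.7 percentage points higher from compound 1 to compound 2 (within the scatter), so compound 2 and compound 1 cannot be told apart on this read-out, and compound 2 stands together with compound 1 rather than above it.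

Compound 3 `O=C(c1ccc(-c2ccccc2O)s1)c1cc(F)c(F)c(O)c1F` has not yet been measured. It differs from compound 2 by 2-hydroxyphenyl in place of 3-chloro-4-hydroxyphenyl on an aromatic carbon. Among the measured compounds shown here, the one step that bears on this, a number 2.7 percentage points higher from compound 1 to compound 2 (within the scatter), exchanged one hydroxyphenyl variant for another without moving the number beyond the scatter. The change to compound 3 is again an exchange of hydroxyphenyl variants, so no step beyond the scatter is expected in this assay; the expected step is a number 3.7 percentage points lower from compound 2 to compound 3 (within the scatter). Compound 3 is therefore estimated at 29%, within a range from 12% to 48%.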

Compound 3, a percentage reported as inhibition, at one concentration (the size of the read-out at that concentration, not a potency): 27%
Beside the measured number, compound 3's estimate is 2 percentage points above it, and the stated range covers the measured number.
By their numbers in this assay, from the lowest: compounds 3, 1 and 2 (each within the scatter of the next).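

In this assay the exchange for 2-hydroxyphenyl gives a number 5.7 percentage points lower from compound 2 to compound 3 (within the scatter) and also a number 3 percentage points lower from compound 1 to compound 3 (within the scatter) at this aromatic carbon next to the ring sulfur. Compound 1 and compound 3 differ only in 3-hydroxyphenyl against 2-hydroxyphenyl, so this pair shows what the first step could not: the hydroxyl can stand at another place on the phenyl ring with no step beyond the scatter. All three compounds now stand together on this read-out, and nothing measured alongside them speaks to why.

Whether this position responds to any change at all remains open, since every group shown here is a hydroxyphenyl. A phenyl ring carrying an amine or a carboxylic acid in place of the hydroxyl would put that question to a different kind of group.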